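The compounds below may be only part of what the source reports. "The series", "measured", "known", "first", "only" and "open" are said of these compounds alone.

Two measured compounds open this small series. Compound 1 `Cn1cnc2c1c(=O)n(CC(=O)OC(C)(C)C)c(=O)n2C` carries a tert-butyl ester on its core, while compound 2 `Cn1cnc2c1c(=O)n(CC(=O)N1CCN(C(=O)OC(C)(C)C)CC1)c(=O)n2C` carries the same core joined through an amide to a piperazine that ends in a tert-butoxycarbonyl group. In a functional assay on MGC-803 cells (Homo sapiens) for inhibition, read by MTT assay, with a stated time of 48 h, tested at 20 uM (on this read-out higher numbers stand for more inhibition at the one concentration tested (going by the name of the read-out) and lower numbers for less inhibition), compound 1 gives 17.2% and compound 2 gives 20%. Compound 2 stands at the top of these two numbers, yet the gap to compound 1 is within the scatter of repeated measurements, so the two results cannot be told apart in any real sense.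

Compound 3 `Cn1cnc2c1c(=O)n(CC(=O)N1CCN(C(=O)/C=C/c3ccccc3)CC1)c(=O)n2C` has not yet been measured. It differs from compound 2 in one place: 2-phenylethenyl in place of tert-butoxy on a carbonyl carbon. For the measured compounds named here, no pair of measured compounds here shares this change, so nothing measured speaks to its size or direction.

The expected step of a number 8 percentage points higher from compound 2 to compound 3 (within the scatter) is a small rise that barely reaches beyond the scatter. Compound 3 is therefore expected to give about 28% in this assay, with a likely range from 10% to 50%.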

Compound 3, a percentage reported as inhibition, at one concentration (the size of the read-out at that concentration, not a potency): 9.5%
Beside the measured number, compound 3's estimate is 18.5 percentage points above it, outside the stated range (below it).
By their numbers in this assay, from the lowest: compounds 3, 1 and 2 (each within the scatter of the next, the first and the last beyond it).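

In this assay, putting 2-phenylethenyl in place of tert-butoxy on the carbonyl carbon, whose other neighbour is the amide-type nitrogen in the ring, gives a number 10.5 percentage points lower from compound 2 to compound 3 (beyond the scatter). For the compounds shown here, this is the first comparison between compounds that differ in one place, and it shows that the group on this carbonyl carbon can shift the read-out by a modest but real amount, with the exchange here lowering inhibition at the one concentration tested. Nothing available explains this drop, so the data record its direction and size but not its cause.

This single exchange changes several things at once: an oxygen-linked tert-butyl group leaves, while an aromatic ring of carbon and a double bond outside that ring enter, so the part responsible for the lower number cannot be singled out. The compounds shown leave open whether 2-phenylethyl, which keeps the ring without that double bond, or a phenyl group placed directly on the same carbonyl carbon would read closer to compound 2 or to compound 3.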